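Bromo for Methoxycarbonyl on the Benzyl Ring: Cytotoxicity Outlook

This account rests on a few compounds, and the source may have more. Where it says the series, first, only, none or still open, it means among the compounds named here.

Compound 1 `CCOC(=O)c1cnc(N2CCN(Cc3cccc(F)c3)CC2)nc1Oc1c(C)cc(-c2ccc(C#N)cc2)cc1C`: in an ADME assay on MT4 cells (Homo sapiens) for cytotoxicity, read by MTT assay, with a stated time of 4 days (a higher number here means that more compound is tolerated, a lower number that less compound is tolerated), compound 1 gives > 125000 nM, which is a limit of the assay and not a number.
Compound 2 `CCOC(=O)c1cnc(N2CCN(Cc3ccccc3F)CC2)nc1Oc1c(C)cc(-c2ccc(C#N)cc2)cc1C`: in this assay compound 2 gives > 125000 nM, again a limit.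
Compound 3 `CCOC(=O)c1cnc(N2CCN(Cc3cccc(C(=O)OC)c3)CC2)nc1Oc1c(C)cc(-c2ccc(C#N)cc2)cc1C`: in this assay compound 3 gives > 125000 nM, again a limit.

Compound 3 therefore stands exactly where the other two stand, at the limit of > 125000 nM in this assay, at which 3 of the 3 values shown sit. Every value is a limit. None of the three compounds can be told apart from another: the step that the two limits leave unreadable from compound 1 to compound 2 is unreadable, as are a step that the two limits leave unreadable from compound 1 to compound 3 and a step that the two limits leave unreadable from compound 2 to compound 3. The shared core tolerates each of the three benzyl substituents up to the highest concentration tested.

The next compound, compound 4 `CCOC(=O)c1cnc(N2CCN(Cc3cccc(Br)c3)CC2)nc1Oc1c(C)cc(-c2ccc(C#N)cc2)cc1C`, differs from compound 3 by bromo in place of methoxycarbonyl on an aromatic carbon. Among the measured compounds shown here, no measured step involves a bromo group, so the only guide is that swapping fluoro for methoxycarbonyl on this same ring left nothing readable. The step is therefore expected to be a number no higher from compound 3 to compound 4 (the limit leaves the size open), with no change beyond the scatter. Compound 4 is expected to give 125000 nM in this assay, between 60000 nM and 250000 nM, most likely reported once more only as a limit.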

Compound 4, half-maximal cytotoxic concentration: > 125000 nM
Compound 4 ended at the assay's limit; the forecaster's own chance of this, stated with the estimate: 80%; the middle value sits exactly at the limit.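

In this assay compound 4 gives > 125000 nM, which is a limit and not a number. Its steps from compound 1, compound 2 and compound 3 therefore cannot be read. The compounds shown leave open how much of each compound the cells would tolerate past this ceiling, and whether the four benzyl substituents differ at all: the limit of > 125000 nM in this assay, at which 4 of the 4 values shown sit.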